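The compounds below may be only part of what the source reports. "The series", "measured", "known", "first", "only" and "open" are said of these compounds alone.

In an ADME assay on CCRF-CEM cells (Homo sapiens) for cytotoxicity, with a stated time of 72 h (on this read-out lower numbers stand for stronger inhibition and higher numbers for weaker inhibition), compound 3 `Clc1ccc(Cc2nn3c(Br)c(-c4ccccc4)nc3s2)cc1` reaches only a limit, > 250000 nM. Compound 2 `Clc1ccc(Cc2nn3c(Br)c(-c4ccc(Br)cc4)nc3s2)cc1` gives 238000 nM in this assay, so that the change bromo in place of hydrogen on an aromatic carbon made a step of an at least 1.0-fold lower number from compound 3 to compound 2 (0.02 log units; that floor lies within the scatter). Compound 1 `O=c1oc2ccccc2cc1-c1cn2nc(Cc3ccc(Cl)cc3)sc2n1` also reaches only a limit in this assay, > 10000 nM. The difference between the core of compound 1 and that of compound 3 is not broken down here. Compound 4 `O=c1oc2ccccc2cc1-c1nc2sc(Cc3ccc(Cl)cc3)nn2c1Br` carries the same kind of change, (bromo in place of hydrogen on an aromatic carbon), though here the place is an aromatic carbon of a five-membered aromatic ring with two nitrogen in a fused system, not a six-membered ring of carbon only para to a large group. From compound 1 to compound 4 a step that the limit leaves unreadable from compound 1 to compound 4 is expected, resting on the step of an at least 1.0-fold lower number from compound 3 to compound 2 (0.02 log units; that floor lies within the scatter) that lay within the scatter. Compound 4 is therefore estimated at 25000 nM, between 7000 nM and 120000 nM.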

Compound 4, half-maximal inhibitory concentration: 3700 nM
Beside the measured number, compound 4's estimate is 6.8-fold (0.83 log units) above it, and the stated range ends above it.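

In this assay, bromo in place of hydrogen on an aromatic carbon of a five-membered aromatic ring with 2 nitrogen gave an at least 2.7-fold lower number from compound 1 to compound 4 (0.43 log units; beyond the scatter), so on this core the change shows a step beyond the scatter. This does not show that the change carries the same size of step from core to core, and the bromo also stands at a different place in the two pairs: the same change on two cores in this assay, an at least 1.0-fold lower number (0.02 log units; that floor lies within the scatter) from compound 3 to compound 2 and an at least 2.7-fold lower number (0.43 log units; beyond the scatter) from compound 1 to compound 4; the limit leaves it open whether they differ. On these data alone, compound 1 gives only a limit, > 10000 nM, and the full size of its step stays unknown.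

As far as these compounds go, what a chloro, a methyl or an amine would give on that same carbon remains open. Also open, from the compounds shown here alone, is whether a carboxylic acid in place of the chlorine would shift these values.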